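The compounds below may be only part of what the source reports. "The series", "measured", "known", "first", "only" and "open" are said of these compounds alone.

Measured compounds in a functional assay for inhibition, with Mus musculus as the target; a higher number here means a weaker inhibitor, a lower number a stronger inhibitor:

- compound 1, `C#CCN(Cc1ccc2nc(C)nc(O)c2c1)c1ccc(C(=O)N[C@@H](CCC(=O)O)C(=O)N[C@@H](CCC(=O)O)C(=O)O)cc1`: 2700 nM
- compound 2, `C#CCN(Cc1cc2c(O)nc(C)nc2cc1C)c1ccc(C(=O)N[C@@H](CCC(=O)O)C(=O)N(CC#C)[C@@H](CCC(=O)O)C(=O)O)c(F)c1`: 570 nM
- compound 3, `C#CCN(Cc1ccc2nc(C)nc(O)c2c1)c1ccc(C(=O)N[C@@H](CC(C)(C)C(=O)O)C(=O)N[C@@H](CCC(=O)O)C(=O)O)cc1`: 1200 nM

Compound 1 has the highest number of the three in this assay; compound 3 sits nearest it, compound 2 furthest. Among the measured compounds shown here, the one single-place step measured in the set is a 2.3-fold lower number from compound 1 to compound 3 (0.35 log units; beyond the scatter), a modest shift at a saturated chain carbon. Compound 2 differs from compound 1 in several places at once, so its lower number cannot be assigned to any one change.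

Compound 4, `C#CCN(Cc1ccc2nc(C)nc(O)c2c1)c1ccc(C(=O)N[C@@H](CCC(=O)O)C(=O)N(C)CC(=O)O)cc1`, is to be measured. It differs from compound 1 as follows: (carboxymethyl)(methyl)amino in place of (1,3-dicarboxypropyl)amino on a carbonyl carbon. For the measured compounds named here, this is a change at the carbonyl carbon, not at the chain carbon touched by the step from compound 1 to compound 3, so no measured step bears directly on it. The change removes the 1,3-dicarboxypropyl part of the chain entirely, a larger alteration than any measured here. With no guide in the data, the expectation for compound 4 is a higher number, step a 2.2-fold higher number from compound 1 to compound 4 (0.35 log units; beyond the scatter), with wide uncertainty. Compound 4 is estimated at 6000 nM, range 1500 nM to 25000 nM.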

Compound 4, half-maximal inhibitory concentration: 7400 nM
Compound 4: middle estimate off by 1.2-fold (0.09 log units), on the low side; measured number inside the range.
By their numbers in this assay, from the lowest: compound 2; then compound 3; then compound 1; then compound 4.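

In this assay the replacement at the carbonyl carbon gives a 2.7-fold higher number from compound 1 to compound 4 (0.44 log units; beyond the scatter) and so shows that this position, which the step at the saturated chain carbon did not touch, also responds to change. The step is modest for so large an alteration: the 1,3-dicarboxypropyl part, with its defined stereocentre, can be removed entirely and compound 4 still gives a measurable 7400 nM in this assay. No supporting measurement bears on this step, and its origin stays unexplained. The change alters chain length, the number of carboxylic acids and the methyl on the nitrogen together, and these contributions cannot be separated here. Open too, from the compounds shown here alone, is how (carboxymethyl)amino without the methyl, or a longer chain ending in a primary amide, would read on this carbonyl carbon.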